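This account rests on a few compounds, and the source may have more. Where it says the series, first, only, none or still open, it means among the compounds named here.

Of the compounds shown here, two built on a shared core have been measured so far. In a functional assay on MCF7 cells (Homo sapiens) for inhibition, read by MTT assay, with a stated time of 48 h (a higher number here means a weaker inhibitor of growth, a lower number a stronger inhibitor of growth), compound 1 (`COc1ccc2c(c1)c(C1CC(c3ccc(Cl)cc3)=NN1C(=O)c1ccc(OC)nc1)cn2C`) gives 3710 nM, and compound 2 (`COc1cccc(C2=NN(C(=O)c3cccnc3)C(c3cn(C)c4ccc(OC)cc34)C2)c1`) gives 810 nM. Compound 2 thus holds the lower of the two numbers, and its gap to compound 1 lies beyond the usual scatter. Compound 3 (`COc1cccc(C2=NN(C(=O)c3ccc(OC)nc3)C(c3cn(C)c4ccc(OC)cc34)C2)c1`) departs from compound 2 in one place: methoxy in place of hydrogen on an aromatic carbon. This is methoxy in place of hydrogen on an aromatic carbon, next to the ring nitrogen, turning pyridin-3-yl into 6-methoxypyridin-3-yl. Going by the values given here, no step between measured compounds isolates this change. Compound 1 carries the same 6-methoxypyridin-3-yl group and gives 3710 nM, but it also differs from compound 2 elsewhere, so that value offers only a loose hint. On that hint, a moderate weakening in this assay is expected, with an expected size of a 1.9-fold higher number from compound 2 to compound 3 (0.27 log units; within the scatter). For compound 3 the estimated value is 1500 nM, with an expected range from 500 nM to 4500 nM.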

Compound 3, concentration for 50% growth inhibition: 130 nM
Beside the measured number, compound 3's estimate is 12-fold (1.06 log units) above it; measured number outside the range, below it.
By their numbers in this assay, from the lowest: compound 3; then compound 2; then compound 1.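

In this assay, the step from pyridin-3-yl to 6-methoxypyridin-3-yl is a 6.2-fold lower number from compound 2 to compound 3 (0.79 log units; beyond the scatter), so methoxy in place of hydrogen next to the ring nitrogen goes with stronger growth inhibition here, and the high number of compound 1 gave no sign of this. Going by these compounds alone, with the 6-methoxypyridin-3-yl group held constant, 3-methoxyphenyl in place of 4-chlorophenyl on the carbon with a double bond to nitrogen gives a 29-fold lower number from compound 1 to compound 3 (1.46 log units; beyond the scatter), a larger step than the one for the methoxy change, and this separates the contribution of that aryl group from the methoxy change that compound 1 had left entangled with it. Nothing available explains why either change moves the number as it does.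

As far as these compounds go, whether ethoxy, a dimethylamino group or a chlorine atom at this same place next to the ring nitrogen would give a step like that of methoxy remains open. So does whether the methoxy step carries over to a compound with the 4-chlorophenyl group, since the one step shown for it has 3-methoxyphenyl at the other end of the molecule.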